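Swapping Hydroxy for Dimethylamino on the Shared Core

The source may report more compounds than this note shows. Statements on the series, on what has been measured and on what is new or still open speak of the compounds shown alone.

Results so far in a functional assay on U-937 cells (Homo sapiens) for antiproliferative activity, with a stated time of 48 h (on this read-out higher numbers stand for an effect only at larger amounts of compound and lower numbers for an effect already at smaller amounts), are as follows.
- compound 1 `O=C(CCCCCCC(=O)Nc1ccc(O)cc1)NO` gives 6400 nM
- compound 2 `O=C(CCCCCCC(=O)Nc1cccc(C(F)(F)F)c1)NO` gives 1200 nM
- compound 3 `O=C(CCCCCCC(=O)Nc1cccc(Cl)c1)NO` gives 350 nM

Compound 1 has the highest number of the three, so more of it is needed for the same effect. Compound 2 and compound 3 both need less.

The next compound is compound 4 `CN(C)c1ccc(NC(=O)CCCCCCC(=O)NO)cc1`, still unmeasured. It keeps the core of compound 1 and changes one group, dimethylamino in place of hydroxy on an aromatic carbon.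

Within the data shown here, only one measured step links two compounds through a single change, a 3.4-fold lower number from compound 2 to compound 3 (0.54 log units; beyond the scatter). That step swaps trifluoromethyl for chloro, so neither group in it is involved here, and it offers only a rough guide to how far one swap on an aromatic carbon can move the number in this assay. Among the measured compounds shown here, no measured pair tests the hydroxy group directly.

Compound 1 sits at the top of the range, and compound 3 at 350 nM shows how much lower this series can go, so a drop of similar size to that one step is expected. The expected change is a 3.6-fold lower number from compound 1 to compound 4 (0.55 log units; beyond the scatter). For compound 4 the estimated value is 1800 nM, with an expected range from 500 nM to 5500 nM.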

Compound 4, half-maximal effective concentration: 1700 nM
Compound 4: the middle estimate sits 1.1-fold (0.02 log units) above what was measured; the range from low to high includes it.
By their numbers in this assay, from the lowest: compound 3; then compounds 2 and 4 (each within the scatter of the next); then compound 1.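

In this assay, putting dimethylamino in place of hydroxy gives a 3.8-fold lower number from compound 1 to compound 4 (0.58 log units; beyond the scatter), the first single change shown on an aromatic carbon para to a large group. Among these compounds, what sits at this place on the ring can therefore shift the number beyond the usual scatter, a point the earlier compounds could not make, as their one measured step involved other groups. The hydrogen-bond donor of hydroxy is also not needed to keep the effect in this pair, as compound 4, with no donor in that group, has the lower number, but no measurement at hand explains the shift.

This one pair cannot separate the loss of hydroxy from the arrival of dimethylamino, as both happen in the same step, and a methoxy group or a simple primary amine at the same place would help pull those two apart. It also leaves open how far the trend runs with other groups at this place, such as a carboxylic acid, and whether the step would keep its size on a longer chain between the hydroxamic acid end and the ring.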